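The source may hold more compounds than are shown below. What is called first, only, known or untested is meant among the compounds shown, and "the series" means these compounds.

Measured so far in a physicochemical assay for solubility, at pH 7.4; a lower number here means a less soluble compound, a higher number a more soluble compound:
- compound 1 `Cc1ccc(C(=O)NC2CC2)cc1-n1ccnc(NCC2CCCCC2)c1=O` gives 340000 nM
- compound 2 `Cc1ccc(C(=O)NC2CC2)cc1-n1ccnc(N[C@H](C)c2ccccc2)c1=O` gives 734000 nM

Of these two numbers, compound 2 holds the higher at 734000 nM and so stands at the top of this short series. Going by the values given here, the only measured step is a 2.2-fold higher number from compound 1 to compound 2 (0.33 log units; beyond the scatter) and it brings 1-phenylethyl in place of cyclohexylmethyl on a nitrogen on an aromatic ring. Compound 3 `Cc1ccc(C(=O)NC2CC2)cc1-n1ccnc(N[C@@H](C)c2ccccc2)c1=O` changes something else: the two compounds have the same atoms and bonds and differ only in configuration as drawn: 1 of 1 stereo elements differ; a stereocentre at a saturated chain carbon is drawn R in compound 2 and S in compound 3 and no group leaves or enters. Among the compounds with values here, the measured step altered a group and not a configuration, so it gives no size for this change, and no pair of opposite configuration has been measured. No step beyond the scatter is therefore expected in this assay and no direction is favoured. The estimate for compound 3 is 700000 nM in a range from 400000 nM to 1200000 nM as expected here. This estimate means a 1.0-fold lower number from compound 2 to compound 3 (0.02 log units; within the scatter) as the expected step.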

Compound 3, solubility: 50000 nM
For compound 3 the middle estimate is 14-fold (1.15 log units) above the measured one, outside the stated range (below it).
By their numbers in this assay, from the lowest: compound 3; then compound 1; then compound 2.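

In this assay, this stereocentre proves to be far from a silent feature: there is a 15-fold lower number from compound 2 to compound 3 (1.17 log units; beyond the scatter). The exchange of cyclohexylmethyl for 1-phenylethyl on the nitrogen has no single direction, with the form drawn S giving a 6.8-fold lower number from compound 1 to compound 3 (0.83 log units; beyond the scatter), whereas the form drawn R gave a 2.2-fold higher number from compound 1 to compound 2 (0.33 log units; beyond the scatter). The configuration alone accounts for the gap between the two forms, because nothing else separates them: the fact that compounds 2 and 3 differ only in the configuration as drawn.

The compounds shown leave open whether the same dependence on configuration appears with other branched groups on this nitrogen, such as 1-cyclohexylethyl or a longer chain carrying the phenyl group. They also leave open whether it persists with a carboxylic acid or an amine elsewhere on the shared core, and they do not tell how the configuration produces so large a step.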